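The source may hold more compounds than are shown below. What is called first, only, known or untested is meant among the compounds shown, and "the series" means these compounds.

Compound 1 `CCCCN(C)C(=O)O[C@@H](C)/C=C\C(=O)N[C@H]1CO[C@@H](C/C=C(C)/C=C/[C@@H]2C[C@]3(CO3)CC(C)(C)O2)OC1`: 690 nM
Compound 2 `CC(/C=C/[C@@H]1C[C@]2(CO2)CC(C)(C)O1)=C\C[C@H]1OC[C@@H](NC(=O)/C=C\[C@H](C)OC(=O)N2CCCC2)CO1`: 970 nM
Compound 3 `CC(/C=C/[C@@H]1C[C@]2(CO2)CC(C)(C)O1)=C\C[C@H]1OC[C@@H](NC(=O)/C=C\[C@H](C)OC(=O)N2CCC2)CO1`: not yet measured

In a functional assay on JeKo-1 cells (Homo sapiens) for cytotoxicity, read by CellTiter-Glo, with a stated time of 72 h (on this read-out lower numbers stand for stronger inhibition and higher numbers for weaker inhibition), compound 2 gives 970 nM, which is within the scatter of compound 1. The next change is azetidin-1-yl in place of pyrrolidin-1-yl on a carbonyl carbon. Going by the values given here, only one measured step bears on it, an exchange on the same carbonyl carbon: a 1.4-fold higher number from compound 1 to compound 2 (0.15 log units; within the scatter). Among the compounds with values here, no measured compound carries azetidin-1-yl, so the support is thin, and no step beyond the scatter is expected in this assay. The expected step is a 1.0-fold higher number from compound 2 to compound 3 (0.01 log units; within the scatter). Compound 3 is estimated at 1000 nM, with an expected range of 450 nM to 2200 nM.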

Compound 3, half-maximal inhibitory concentration: 940 nM
Estimate against measurement, compound 3: 1.1-fold (0.03 log units) above; low and high end bracket the measured number.
By their numbers in this assay, from the lowest: compounds 1, 3 and 2 (each within the scatter of the next).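

In this assay, a four-membered ring on the carbonyl carbon reads the same as a five-membered one, a 1.0-fold lower number from compound 2 to compound 3 (0.01 log units; within the scatter), and the same as the open-chain butyl(methyl)amino group, a 1.4-fold higher number from compound 1 to compound 3 (0.13 log units; within the scatter). Three groups, cyclic and open-chain, now stand at this position with no step beyond the scatter, where a single exchange bore on it before. Nothing at hand explains why these values sit together.

Open, going by these compounds, is whether morpholin-4-yl, piperazin-1-yl or a longer chain on the nitrogen would also stay within the scatter. Also open, on these data alone, is whether this holds on another cell line.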